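The source may hold more compounds than are shown below. What is called first, only, known or untested is meant among the compounds shown, and "the series" means these compounds.

Measured compounds:
compound 1 `Fc1ccc(OC[C@@H]2CCN2)cn1` with 0.057 nM
compound 2 `CCc1ccc(OC[C@@H]2CCN2)cn1` with 19 nM
compound 3 `Clc1cncc(OC[C@@H]2CCN2)c1` with 0.042 nM

In an assay on brain for binding affinity to Neuronal acetylcholine receptor; alpha4/beta2 (Rattus norvegicus), read by radioligand binding (on this read-out higher numbers stand for weaker inhibition and lower numbers for stronger inhibition), compound 3 gives the lowest number of the three, close to compound 1 and far from compound 2. Compound 4 `O=[N+]([O-])c1cncc(OC[C@@H]2CCN2)c1` is not yet measured. It differs from compound 3 in one place: nitro in place of chloro on an aromatic carbon.

Among the compounds with values here, only one step between measured compounds is available, and it does not match this change directly: a 330-fold higher number from compound 1 to compound 2 (2.52 log units; beyond the scatter). It shows that replacing a small halogen on the aromatic carbon with an alkyl group costs a great deal in this assay. Within the data shown here, the change from compound 3 to compound 4 exchanges chloro for nitro, a group that is neither the halogen nor the ethyl of the measured pair, so the step has no close precedent here. Since the compounds carrying a halogen at this position, compound 1 and compound 3, both give very low numbers, a nitro group is expected to stay closer to those than to compound 2, with some loss allowed for the larger group: compound 4 is estimated at 0.2 nM, with a range from 0.04 nM to 1.5 nM, meaning an expected step of a 4.8-fold higher number from compound 3 to compound 4 (0.68 log units; beyond the scatter).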

Compound 4, inhibition constant: 0.33 nM
Beside the measured number, compound 4's estimate is 1.7-fold (0.22 log units) below it, within the range that was stated.
By their numbers in this assay, from the lowest: compounds 3 and 1 (each within the scatter of the next); then compound 4; then compound 2.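

In this assay, the exchange of chloro for nitro, on an aromatic carbon two atoms from the ring nitrogen, is the only change shown at this position, and it gives a 7.9-fold higher number from compound 3 to compound 4 (0.90 log units; beyond the scatter). The position therefore takes a nitro group, with three heavy atoms and two hydrogen-bond acceptors in place of a single chlorine, at a measurable cost that the step itself rates as modest rather than large, and compound 4 still gives a low number at 0.33 nM. No measurement offered here explains this cost, so the cause of the step remains unknown.

As far as these compounds go, whether an amine, a nitrile or a carboxylic acid on the same aromatic carbon would stay near compound 3, fall near compound 4 or lose far more remains open. Also open is whether nitro in place of a halogen would bring a step of similar size on the core of compound 1, since the one exchange shown here rests on a single pair of compounds.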